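This account rests on a few compounds, and the source may have more. Where it says the series, first, only, none or still open, it means among the compounds named here.

Three compounds share one core, each carrying a different sulfonyl group on the sulfonamide nitrogen: compound 1 `O=S(=O)(Nc1ccc2oc(-c3ccccc3)nc2c1)c1cccc(C(F)(F)F)c1`, compound 2 `Cc1ccccc1S(=O)(=O)Nc1ccc2oc(-c3ccccc3)nc2c1` and compound 3 `O=S(=O)(Nc1ccc2oc(-c3ccccc3)nc2c1)c1cccc(Cl)c1`. In an assay on cells for inhibition of HSP60/HSP10 (Homo sapiens), with a stated time of 60 min (a higher number here means a weaker inhibitor, a lower number a stronger inhibitor), compound 1 gives > 100000 nM, which is a limit of the assay and not a number. In this assay compound 2 gives > 100000 nM, again a limit. Compound 3 gives > 100000 nM, which is a limit as well. Compound 3 therefore stands where every value shown stands, and the two steps that lead to it, a step that the two limits leave unreadable from compound 1 to compound 3 and a step that the two limits leave unreadable from compound 2 to compound 3, have no readable size because of the limit of > 100000 nM in this assay, at which 3 of the 3 values shown sit.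

Compound 4 `O=S(=O)(Nc1ccc2oc(-c3ccccc3)nc2c1)c1ccc(Cl)s1` has not yet been measured in this assay. It differs from compound 3 in one place: 5-chlorothiophen-2-yl in place of 3-chlorophenyl on a sulfonyl sulfur. For the measured compounds named here, the only measured steps that bear on this change are the two unreadable ones into compound 3, so no size can be drawn from them, and the shared limit gives no reason to expect a step beyond the scatter in either direction. Compound 4 is accordingly expected to sit at the limit too, and its value in this assay is estimated at 100000 nM, in a range from 20000 nM to 500000 nM. The expected step is a number no higher from compound 3 to compound 4 (the limit leaves the size open).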

Compound 4, half-maximal inhibitory concentration: 70000 nM
Beside the measured number, compound 4's estimate is 1.4-fold (0.15 log units) above it, within the range that was stated.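

In this assay compound 4 gives 70000 nM, the first value shown here that is a number and not a limit, so a change on the sulfonyl sulfur alone can yield a reading within the range of the assay. Putting 5-chlorothiophen-2-yl in place of 3-chlorophenyl gives an at least 1.4-fold lower number from compound 3 to compound 4 (0.15 log units; that floor lies within the scatter), and putting it in place of 2-methylphenyl gives an at least 1.4-fold lower number from compound 2 to compound 4 (0.15 log units; that floor lies within the scatter), so each step has only a floor, and that floor alone sets no order among these compounds. Going by these compounds, the true size of both steps stays open because the compounds on the other side of them give no number: the limit of > 100000 nM in this assay, at which 3 of the 4 values shown sit.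

The compounds shown leave open how a thiophen-2-yl group without the chlorine would read in this assay, and whether an amine or a carboxylic acid on that ring would give a lower number. They also say nothing about changes to the shared core, which is the same in all four compounds.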